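The compounds below may be only part of what the source reports. "The series", "measured", "known", "first", "only" and "open" are said of these compounds alone.

Measured in an assay for inhibition of Fatty-acid amide hydrolase 1 (Rattus norvegicus); on this read-out lower numbers stand for stronger inhibition and higher numbers for weaker inhibition:
- compound 1 `O=C(O)c1ccc(CCCCCCC(=O)c2ncc(-c3ccccn3)o2)cc1` gives > 600 nM, which is a limit of the assay.
- compound 2 `O=C(CCCCCCc1cccc(Cl)c1Cl)c1ncc(-c2ccccn2)o1` gives 0.9 nM.
- compound 3 `O=C(CCCOCCc1ccccc1)c1ncc(-c2ccccn2)o1` gives 63 nM.

Among the measured compounds shown here, compound 2 holds the lowest of the two numbers given; compound 3 gives the nearest number, and no step between those two is computed, so their values simply stand side by side. Compound 1 sits at the limit of > 600 nM in this assay, at which 1 of the 3 values shown sits. For the measured compounds named here, the one computed step is an at least 660-fold lower number from compound 1 to compound 2 (2.82 log units; beyond the scatter), a large drop.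

Compound 4 `O=C(CCCCCC(O)c1ccccc1)c1ncc(-c2ccccn2)o1` has not been measured. hydroxy(phenyl)methyl in place of 2,3-dichlorobenzyl on a saturated chain carbon, five bonds along the chain from a carbonyl carbon The ring stays, the two chlorines leave, a hydroxyl appears, and the group now sits five bonds along the chain from a carbonyl carbon instead of six. The step from compound 1 to compound 2 bears on this change, since it shows how much a polar group on that end of the chain raises the number; compound 3, with an oxygen in the chain, also gives a far higher number than compound 2. The step of a 44-fold higher number from compound 2 to compound 4 (1.65 log units; beyond the scatter) is therefore expected upward, clearly beyond the scatter but smaller than the step from compound 1. Compound 4 is estimated at 40 nM, within 8 nM to 200 nM.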

Compound 4, inhibition constant: 35 nM
The estimate for compound 4 lay 1.1-fold (0.06 log units) above the measured number; the range from low to high includes it.
By their numbers in this assay, from the lowest: compound 2; then compounds 4 and 3 (each within the scatter of the next). At a limit, above all of these: compound 1.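

Replacing 2,3-dichlorobenzyl with hydroxy(phenyl)methyl gives a 39-fold higher number from compound 2 to compound 4 (1.59 log units; beyond the scatter) in this assay, so a large rise at this end of the chain occurs even with a six-membered aromatic ring of carbon only on both sides of the change and no net charge on either group. Compound 4 nevertheless gives a measured number, 35 nM. Compound 1, by contrast, stands at a limit and not at a number: the limit of > 600 nM in this assay, at which 1 of the 4 values shown sits.

This single change removes both chlorines, adds a hydroxyl and places the group five bonds along the chain from a carbonyl carbon instead of six, and the compounds shown do not separate these parts. Still open, going by these compounds, is how an unsubstituted phenyl on the same chain would read, and how an amine or a methoxy group in place of the hydroxyl would read.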